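Swapping 4-chlorophenyl for 3-methylthiophen-2-yl: growth inhibition notes

This account rests on a few compounds, and the source may have more. Where it says the series, first, only, none or still open, it means among the compounds named here.

In a functional assay on DU-145 cells (Homo sapiens) for inhibition, read by trypan blue exclusion, with a stated time of 96 h (on this read-out lower numbers stand for stronger inhibition of growth and higher numbers for weaker inhibition of growth), compound 3 `O=C(/C(=C\c1ccc(Cl)cc1)SCc1ccc(Cl)cc1)c1ccc(Br)cc1` gives 10000 nM. Compound 2 `O=C(/C(=C\c1ccc(O)cc1)SCc1ccc(Cl)cc1)c1ccc(Br)cc1` gives 10000 nM, so these two stand level and share the lowest number of the three measured. Compound 1 `Cc1ccc(S/C(=C/c2sccc2C)C(=O)c2ccc(Br)cc2)cc1` gives 50000 nM, the highest number and the furthest from compound 3.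

The next structure is compound 4 `Cc1ccsc1/C=C(/SCc1ccc(Cl)cc1)C(=O)c1ccc(Br)cc1`, which carries 3-methylthiophen-2-yl in place of 4-chlorophenyl on a double-bonded chain carbon bound to a double-bonded chain carbon.

Among the compounds with values here, only one measured step is available, no change at the digits printed from compound 2 to compound 3 (within the scatter), for chloro in place of hydroxy on an aromatic carbon. That step keeps the aromatic ring, so it offers only loose guidance for an exchange of the whole group. The 3-methylthiophen-2-yl group also occurs in compound 1 at 50000 nM, but that compound differs from compound 3 elsewhere too, and the data cannot isolate the contribution of the group. On that basis, only a slight lean towards a higher number is expected in this assay, with no firm expectation of a change beyond the scatter. The expected size of the change is a 1.5-fold higher number from compound 3 to compound 4 (0.18 log units; within the scatter). The estimated value for compound 4 is 15000 nM, with an expected range of 6000 nM to 40000 nM.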

Compound 4, concentration for 50% growth inhibition: 25000 nM
Estimate against measurement, compound 4: 1.7-fold (0.22 log units) below; the measured number falls inside the stated range.
By their numbers in this assay, from the lowest: compounds 2 and 3 (each within the scatter of the next); then compounds 4 and 1 (each within the scatter of the next).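

In this assay this place on a double-bonded chain carbon bound to a double-bonded chain carbon now responds to an exchange of the ring itself: 3-methylthiophen-2-yl in place of 4-chlorophenyl gives a 2.5-fold higher number from compound 3 to compound 4 (0.40 log units; beyond the scatter) and in place of 4-hydroxyphenyl gives a 2.5-fold higher number from compound 2 to compound 4 (0.40 log units; beyond the scatter) while chloro in place of hydroxy on an aromatic carbon gave only no change at the digits printed from compound 2 to compound 3 (within the scatter) in the earlier pair. The two phenyl compounds therefore stand level, and the modest step beyond the scatter appears only when 3-methylthiophen-2-yl enters. With that group held fixed, 4-chlorobenzyl in place of 4-methylphenyl on a sulfur gives a 2.0-fold lower number from compound 1 to compound 4 (0.30 log units; within the scatter) and so does not separate the two groups on the sulfur.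

Nothing available bears on why the ring exchange shifts the number.

Still open, from the compounds shown here alone, is whether the step belongs to the thiophene ring or to its methyl group, which thiophen-2-yl without the methyl group would test, and whether a pyridine ring or a phenyl ring carrying an amine or a carboxylic acid at this place would stay level with compound 2 and compound 3 or move away from them.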